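A few compounds are considered here, and "the series" means these few. Any claim that something is new, unique, unknown or untested is made for them only; others in the source may bear on it.

Compound 1 `Cc1nc(N)nc(N[C@@H]2C[C@H](CO)[C@@H](O)[C@H]2O)c1-c1nc2ccccc2s1` gives 1820 ng.h/mL in an ADME assay on the whole organism (plasma) for pharmacokinetics, with Rattus norvegicus as the target, with a stated time of 6 h, at a dose of 10 mg/kg by the oral route; a higher number here means more compound in the circulation at the dose given, a lower number less compound in the circulation. Compound 2 `Cc1nc(NCCCC(F)(F)F)nc(N[C@@H]2C[C@H](CO)[C@@H](O)[C@H]2O)c1-c1nc2ccccc2s1` gives 1040 ng.h/mL. Compound 3 `Cc1nc(NCc2ccccc2)nc(N[C@@H]2C[C@H](CO)[C@@H](O)[C@H]2O)c1-c1nc2ccccc2s1` gives 1050 ng.h/mL.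

Compound 3 sits within the usual scatter of both other compounds: a 1.7-fold lower number from compound 1 to compound 3 (0.24 log units; within the scatter) and a 1.0-fold higher number from compound 2 to compound 3 (0.00 log units; within the scatter). Compound 4 `Cc1nc(NCc2ccncc2)nc(N[C@@H]2C[C@H](CO)[C@@H](O)[C@H]2O)c1-c1nc2ccccc2s1` differs from compound 3 in one place: pyridin-4-yl in place of phenyl on a saturated chain carbon bound to a nitrogen on an aromatic ring. Going by the values given here, no measured step exchanges a phenyl for a pyridin-4-yl, so the bearing steps are only the neighbouring ones, a 1.7-fold lower number from compound 1 to compound 3 (0.24 log units; within the scatter) and a 1.0-fold higher number from compound 2 to compound 3 (0.00 log units; within the scatter), each within the scatter. On that basis no change beyond the scatter is expected in this assay from compound 3 to compound 4. Compound 4 is therefore estimated at 900 ng.h/mL, with a range of 350 ng.h/mL to 2400 ng.h/mL, which is expected to mean a 1.2-fold lower number from compound 3 to compound 4 (0.07 log units; within the scatter).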

Compound 4, area under the concentration-time curve: 47.9 ng.h/mL
Beside the measured number, compound 4's estimate is 19-fold (1.27 log units) above it; measured number below the stated range.
By their numbers in this assay, from the lowest: compound 4; then compounds 2, 3 and 1 (each within the scatter of the next).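

At this position, this assay had not separated a hydrogen, a 4,4,4-trifluorobutyl group and a benzyl group beyond the scatter, yet pyridin-4-yl in place of phenyl gives a 22-fold lower number from compound 3 to compound 4 (1.34 log units; beyond the scatter) and is a large step. Pyridin-4-yl in place of 3,3,3-trifluoropropyl gives a 22-fold lower number from compound 2 to compound 4 (1.34 log units; beyond the scatter) as well, and (pyridin-4-yl)methyl in place of hydrogen gives a 38-fold lower number from compound 1 to compound 4 (1.58 log units; beyond the scatter) as the largest step here. Going by these compounds alone, the position therefore tolerates some groups without a clear change, but not this one, and a single ring nitrogen in the benzyl group is the only difference between compound 3 and compound 4.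

On these data alone, whether the place of that nitrogen in the ring matters remains open, as does the outcome with pyridin-3-yl or pyridin-2-yl at this position. Nothing available here explains the fall in compound 4.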